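Furan-2-yl for pyridin-2-yl: expectation for compound 4

The source may hold more compounds than are shown below. What is called first, only, known or untested is meant among the compounds shown, and "the series" means these compounds.

Compound 1 `Oc1cccc(-c2cc(-c3ccc(Cl)cc3)nc(-c3cccnc3)c2)c1` gives 39500 nM in an ADME assay on HEK293 cells (Homo sapiens) for cytotoxicity, read by CCK-8 assay and cell counting, with a stated time of 2 days; a higher number here means a weaker inhibitor, a lower number a stronger inhibitor; compound 2 `Oc1cccc(-c2cc(-c3ccc(Cl)cc3)nc(-c3ccsc3)c2)c1` gives 11200 nM in this assay; compound 3 `Oc1cccc(-c2cc(-c3ccc(Cl)cc3)nc(-c3ccccn3)c2)c1` gives 14000 nM in this assay. Compound 3 thus stands second highest of the three: its gap to compound 2 is within the scatter, while a 2.8-fold lower number from compound 1 to compound 3 (0.45 log units; beyond the scatter). Compound 4 `Oc1cccc(-c2cc(-c3ccc(Cl)cc3)nc(-c3ccco3)c2)c1` carries furan-2-yl in place of pyridin-2-yl on an aromatic carbon. For the measured compounds named here, two measured steps bear on this change. Replacing a six-membered aromatic ring with one hetero atom by a five-membered one gave a 3.5-fold lower number from compound 1 to compound 2 (0.55 log units; beyond the scatter), yet between the two groups nearest to this pair a 1.3-fold higher number from compound 2 to compound 3 (0.10 log units; within the scatter). The change is therefore expected to shift this assay little, at most modestly downward, as a 1.4-fold lower number from compound 3 to compound 4 (0.15 log units; within the scatter). Compound 4 is estimated at 10000 nM, within a range from 4000 nM to 25000 nM.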

Compound 4, half-maximal inhibitory concentration: 8190 nM
The estimate for compound 4 lay 1.2-fold (0.09 log units) above the measured number; the measured number falls inside the stated range.
By their numbers in this assay, from the lowest: compounds 4, 2 and 3 (each within the scatter of the next); then compound 1.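

In this assay, furan-2-yl at this position, next to the ring nitrogen, joins pyridin-2-yl (a 1.7-fold lower number from compound 3 to compound 4 (0.23 log units; within the scatter)) and thiophen-3-yl (a 1.4-fold lower number from compound 2 to compound 4 (0.14 log units; within the scatter)) as a third group within the scatter, so a five-membered aromatic ring does not by itself separate from pyridin-2-yl. Pyridin-3-yl remains the exception, now also set apart from furan-2-yl (a 4.8-fold lower number from compound 1 to compound 4 (0.68 log units; beyond the scatter)). Nothing on hand accounts for this separation. Still open, as far as these compounds go, is whether an aliphatic amine or a carboxylic acid at this position would stay with these three groups or fall nearer compound 1.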